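Replacing the Amide Aryl Group: Compound 2 to Compound 3

This account rests on a few compounds, and the source may have more. Where it says the series, first, only, none or still open, it means among the compounds named here.

Compound 1 `COc1ccc(NC(=O)[C@H]2CCCN2C(=O)C2(c3cccc(Cl)c3)CCCC2)nc1`: in an assay on isolated protein for inhibition of histone acetyltransferase p300 (Homo sapiens), with a stated time of 60 min (on this read-out higher numbers stand for weaker inhibition and lower numbers for stronger inhibition), compound 1 gives 2 nM.
Compound 2 `O=C1Cc2cc(NC(=O)[C@H]3CCCN3C(=O)C3(c4cccc(Cl)c4)CCCC3)ccc2N1`: in this assay compound 2 gives 0.794 nM.

Compound 2 has the lower of the two numbers, and the step of a 2.5-fold lower number from compound 1 to compound 2 (0.40 log units; beyond the scatter) lies beyond the scatter. Compound 3 `O=C(Nc1cnc2[nH]ncc2c1)[C@H]1CCCN1C(=O)C1(c2cccc(Cl)c2)CCCC1` differs from compound 2 by a group of 9 heavy atoms (6 carbon, 3 nitrogen; one five-membered aromatic ring with 2 hetero atoms, one six-membered aromatic ring with 1 hetero atom) in place of a group of 10 heavy atoms (8 carbon, 1 nitrogen, 1 oxygen; one five-membered non-aromatic ring with 1 hetero atom, one six-membered aromatic ring of carbon only), on an amide-type nitrogen. Within the data shown here, the only measured step changes the same position, was modest, and involved neither group concerned here, so guidance is thin. The expected step is a 1.9-fold higher number from compound 2 to compound 3 (0.28 log units; within the scatter), with compound 3 estimated at 1.5 nM, between 0.5 nM and 5 nM.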

Compound 3, half-maximal inhibitory concentration: 15.9 nM
Estimate against measurement, compound 3: 11-fold (1.03 log units) below; the whole stated range lies below it.
By their numbers in this assay, from the lowest: compound 2; then compound 1; then compound 3.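

In this assay the change at this amide-type nitrogen brings a 20-fold higher number from compound 2 to compound 3 (1.30 log units; beyond the scatter) and also an 8.0-fold higher number from compound 1 to compound 3 (0.90 log units; beyond the scatter) so the position tolerates less than the first step alone suggested. Two groups that each carry two rings and a hydrogen-bond donor, as in compound 2 and compound 3, can still sit far apart on this read-out. Nothing available gives a reason for this rise.

Which difference between the entering and leaving groups matters remains open. So does how a phenyl ring carrying an amine would fare on this nitrogen.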